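A few compounds are considered here, and "the series" means these few. Any claim that something is new, unique, unknown or untested is made for them only; others in the source may bear on it.

Within the data shown here, in a functional assay on HEK293T cells for agonist activity at histamine H2 receptor (Homo sapiens), read by beta-arrestin recruitment (on this read-out higher numbers stand for larger maximal responses and lower numbers for smaller maximal responses), compound 2 `CCCCCNC(=O)/N=C(\N)NCCCc1sc(N)nc1C` gives 0.15, the lower of the two numbers known, while compound 1 `CCCNC(=O)/N=C(\N)NCCCc1sc(N)nc1C` gives 0.32. Among the measured compounds shown here, the only measured step, a number 0.17 lower from compound 1 to compound 2 (beyond the scatter), came from lengthening the chain on that amide-type nitrogen. Compound 3 `Cc1nc(N)sc1CCCN/C(N)=N/C(=O)NC(C)c1ccco1` differs from compound 2 by 1-(furan-2-yl)ethyl in place of pentyl on an amide-type nitrogen. Nothing measured here involves a ring at that position, so the expectation for compound 3 in this assay rests loosely on that one step and is estimated as a move of a number 0.070 higher from compound 2 to compound 3 (within the scatter). Compound 3 is accordingly expected to reach 0.22, within roughly 0.05 to 0.4.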

Compound 3, intrinsic activity: the largest response reached, as a fraction of the reference agonist's: 0.25
For compound 3 the middle estimate is 0.030 below the measured one; measured number inside the range.
By their numbers in this assay, from the lowest: compounds 2, 3 and 1 (each within the scatter of the next, the first and the last beyond it).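

In this assay, 1-(furan-2-yl)ethyl on the amide-type nitrogen gives a number 0.10 higher from compound 2 to compound 3 (within the scatter) and a number 0.070 lower from compound 1 to compound 3 (within the scatter), so it cannot be told apart from either pentyl or propyl, although those two chains differ from each other beyond the scatter. This position therefore holds a five-membered aromatic ring without leaving the range of the two chains. No evidence is available to explain this result. From the compounds shown here alone, it remains open whether 1-phenylethyl or 1-(thiophen-2-yl)ethyl at the same nitrogen would read alike, and what a chain longer than pentyl would give.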